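The source may report more compounds than this note shows. Statements on the series, on what has been measured and on what is new or still open speak of the compounds shown alone.

Compound 1 `O=C(COc1ccc(C(=O)/C=C/c2ccc(Cl)cc2Cl)cc1)N[C@H]1CCOC1=O` carries a chalcone-like chain joined through an amide to a small lactone ring. In a functional assay on MCF7 cells (Homo sapiens) for antiproliferative activity, read by MTT assay, with a stated time of 72 h (on this read-out higher numbers stand for weaker inhibition and lower numbers for stronger inhibition), compound 1 gives 34400 nM, the lowest of the two plain numbers seen here. Compound 3 `O=C1OCC[C@@H]1NC(=S)SCCOc1ccccc1Cc1ccccc1` gives 39500 nM in this assay, a value within the usual scatter of that of compound 1. Compound 2 `O=C1OCC[C@@H]1NC(=S)SCCOc1ccc([N+](=O)[O-])cc1` reaches only a limit of the assay, > 64000 nM. Compound 4 `CC(C)(C)c1ccc(/C=C/C(=O)c2ccc(OCC(=O)N[C@H]3CCOC3=O)cc2)cc1` differs from compound 1 by one exchange: 4-(tert-butyl)phenyl in place of 2,4-dichlorophenyl on a double-bonded chain carbon bound to a double-bonded chain carbon. Within the data shown here, no measured pair shows a step of this kind, so compound 4 is expected to stay close to compound 1, with a step of a 1.1-fold lower number from compound 1 to compound 4 (0.06 log units; within the scatter) and an expected value of 30000 nM, within a range from 10000 nM to 90000 nM.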

Compound 4, half-maximal inhibitory concentration: 16400 nM
Compound 4: middle estimate off by 1.8-fold (0.26 log units), on the high side, and the stated range covers the measured number.
By their numbers in this assay, from the lowest: compound 4; then compounds 1 and 3 (each within the scatter of the next). At a limit, above all of these: compound 2.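

In this assay, 4-(tert-butyl)phenyl in place of 2,4-dichlorophenyl on a double-bonded chain carbon bound to a double-bonded chain carbon gives a 2.1-fold lower number from compound 1 to compound 4 (0.32 log units; beyond the scatter), a modest step. This position therefore responds to an exchange of its aromatic group, and the activity seen here does not depend on the two chlorine atoms. Nothing measured here explains the step. As far as these compounds go, whether a phenyl ring carrying an amine or a carboxylic acid at this place would lower the number further remains open. A single exchange also cannot establish a trend.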